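The source may report more compounds than this note shows. Statements on the series, on what has been measured and on what is new or still open speak of the compounds shown alone.

In an ADME assay on HOS cells (Homo sapiens) for cytotoxicity (a lower number here means that less compound is tolerated, a higher number that more compound is tolerated), compound 1 (`CN(Cc1nc2cccc(CCCN)c2[nH]1)C1CCCc2cccnc21`) gives 10000 nM and compound 2 (`CN(Cc1nc2cccc(CCCN3CCCC3)c2[nH]1)C1CCCc2cccnc21`) gives 8200 nM, so the two lie within the scatter of each other. Compound 3 (`CN1CCN(c2cccc3nc(CN(C)C4CCCc5cccnc54)[nH]c23)CC1`) differs from compound 2 as follows: 4-methylpiperazin-1-yl in place of 3-(pyrrolidin-1-yl)propyl on an aromatic carbon, which is 4-methylpiperazin-1-yl in place of 3-(pyrrolidin-1-yl)propyl on an aromatic carbon. Going by the values given here, the only measured step, a 1.2-fold lower number from compound 1 to compound 2 (0.09 log units; within the scatter), alters the chain end and does not cover this replacement, so it is weak guidance. No shift beyond the scatter is therefore expected, and the estimate is a 1.0-fold lower number from compound 2 to compound 3 (0.01 log units; within the scatter). For compound 3 the estimated value is 8000 nM, with an expected range of 3000 nM to 20000 nM.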

Compound 3, half-maximal cytotoxic concentration: 14000 nM
For compound 3 the middle estimate is 1.8-fold (0.24 log units) below the measured one; low and high end bracket the measured number.
By their numbers in this assay, from the lowest: compounds 2, 1 and 3 (each within the scatter of the next).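

In this assay, the change at this aromatic carbon is larger than the earlier change at the chain end, yet a 1.7-fold higher number from compound 2 to compound 3 (0.23 log units; within the scatter) and a 1.4-fold higher number from compound 1 to compound 3 (0.15 log units; within the scatter). The whole propyl chain can thus give way to 4-methylpiperazin-1-yl with no shift beyond the scatter, whether the chain ends in pyrrolidin-1-yl or amino. Nothing available gives a reason for this. From the compounds shown here alone, whether a carboxylic acid or a longer chain on this carbon would also stay within the scatter remains open, as does the effect of any change to the shared core.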